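Oxazolyl in place of pyrazolyl on the fused core

The compounds below may be only part of what the source reports. "The series", "measured", "known", "first", "only" and "open" are said of these compounds alone.

Measured compounds:
compound 1 `CS(=O)(=O)Nc1cccc2c1CCC2c1ncc[nH]1` 70 nM
compound 2 `Cn1cc(-c2cccc3c2CCC3c2ncc[nH]2)cn1` (a limit of the assay)
compound 3 `c1cc(-c2ccn[nH]2)c2c(c1)C(c1ncc[nH]1)CC2` 52 nM

In a functional assay on CHO cells for agonist activity at Alpha-1A adrenergic receptor (Homo sapiens), read by FLIPR and calcium flux (on this read-out lower numbers stand for an effect already at smaller amounts and higher numbers for an effect only at larger amounts of compound), compound 3 gives the lowest of the two numbers measured; compound 1 with 70 nM is its nearest neighbour, and the pair differ by a 1.3-fold lower number from compound 1 to compound 3 (0.13 log units; within the scatter). Compound 2 reaches only a limit of the assay, > 2900 nM (the limit of > 2900 nM in this assay, at which 1 of the 3 values shown sits).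

Compound 4 `c1cc(-c2ncco2)c2c(c1)C(c1ncc[nH]1)CC2` differs from compound 3 in one place: 1,3-oxazol-2-yl in place of 1H-pyrazol-5-yl on an aromatic carbon.

The measured steps that bear on this change are those among the three five-membered or sulfonamide substituents at the same carbon: an at least 41-fold higher number from compound 1 to compound 2 (1.61 log units; beyond the scatter), an at least 55-fold lower number from compound 2 to compound 3 (1.74 log units; beyond the scatter) and a 1.3-fold lower number from compound 1 to compound 3 (0.13 log units; within the scatter). Two of these are large, showing that a small change in the aryl ring at this position can move the number far; the third is within the scatter. Compound 4 carries a ring with no hydrogen-bond donor, as does compound 2, and compound 2 is the weakest measured. The step of a 17-fold higher number from compound 3 to compound 4 (1.24 log units; beyond the scatter) is therefore expected to be a clear rise. Compound 4 is estimated at 900 nM, ranging from 150 nM to 5000 nM.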

Compound 4, half-maximal effective concentration: 170 nM
The estimate for compound 4 lay 5.3-fold (0.72 log units) above the measured number; the range from low to high includes it.
By their numbers in this assay, from the lowest: compounds 3 and 1 (each within the scatter of the next); then compound 4. At a limit, above all of these: compound 2.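

In this assay, a ring with 0 hydrogen-bond donors on this aromatic carbon costs only a modest step when 1,3-oxazol-2-yl replaces 1H-pyrazol-5-yl (a 3.3-fold higher number from compound 3 to compound 4 (0.51 log units; beyond the scatter)), and the step from methanesulfonamido is also modest (a 2.4-fold higher number from compound 1 to compound 4 (0.39 log units; beyond the scatter)). The same ring stands far from 1-methyl-1H-pyrazol-4-yl (an at least 17-fold lower number from compound 2 to compound 4 (1.23 log units; beyond the scatter)), so having 0 hydrogen-bond donors does not by itself bring a compound to the level of compound 2. As far as these compounds go, compound 2 remains a limit of the assay, so the full size of that step stays unknown: (the limit of > 2900 nM in this assay, at which 1 of the 4 values shown sits).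

The compounds shown do not separate the effect of the methyl group in compound 2 from that of the pyrazole's point of attachment. From the compounds shown here alone, how this carbon responds to a non-ring group such as an amine or a carboxylic acid also remains open.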